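Sulfonamide chain shortening on the shared core

A few compounds are considered here, and "the series" means these few. Any claim that something is new, unique, unknown or untested is made for them only; others in the source may bear on it.

Measured compounds:
- compound 1, `CC[C@@H]1C(=O)N(C)c2cnc(-n3ccc4cc(C(N)=O)ccc43)nc2N1C1CCCC1`: 1830 nM in a functional assay on MCF7 cells (Homo sapiens) for antiproliferative activity, read by CCK-8 assay, with a stated time of 72 h; on this read-out higher numbers stand for weaker inhibition of growth and lower numbers for stronger inhibition of growth
- compound 2, `CCCCNS(=O)(=O)c1ccc(Nc2ncc3c(n2)N(C2CCCC2)[C@H](CC)C(=O)N3C)cc1`: 459 nM
- compound 3, `CCNC(=O)c1ccc2c(ccn2-c2ncc3c(n2)N(C2CCCC2)[C@H](CC)C(=O)N3C)c1`: 784 nM

Compound 2 stands apart from compound 1 by a gap beyond the scatter, whereas its gap to compound 3 lies within the scatter, so compound 2 and compound 3 cannot be ordered on these numbers. Compound 4, `CC[C@@H]1C(=O)N(C)c2cnc(Nc3ccc(S(=O)(=O)NC)cc3)nc2N1C1CCCC1`, is not yet measured. It differs from compound 2 by hydrogen in place of propyl on a saturated chain carbon bound to a sulfonamide nitrogen.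

For the measured compounds named here, the only measured step, a 2.3-fold lower number from compound 1 to compound 3 (0.37 log units; beyond the scatter), concerns an amide-type nitrogen and adds a chain rather than removing one; it is the nearest comparison, and it shows a modest gain when a small alkyl is added at a nitrogen of this kind. Going by the values given here, no measured pair changes the sulfonamide substituent itself, so the bearing of that step is indirect. Given that removal of the propyl is the opposite direction of change, a modest rise in the number is expected for compound 4, a 1.6-fold higher number from compound 2 to compound 4 (0.21 log units; within the scatter), with wide uncertainty. The estimate for compound 4 in this assay is 750 nM, between 300 nM and 1900 nM.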

Compound 4, concentration for 50% growth inhibition: 151 nM
For compound 4 the middle estimate is 5.0-fold (0.70 log units) above the measured one, outside the stated range (below it).
By their numbers in this assay, from the lowest: compound 4; then compounds 2 and 3 (each within the scatter of the next); then compound 1.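

In this assay, for the compounds shown here, butylsulfamoyl to methylsulfamoyl is the only measured change at the sulfonamide substituent, and a 3.0-fold lower number from compound 2 to compound 4 (0.48 log units; beyond the scatter) shows that the propyl on a saturated chain carbon bound to a sulfonamide nitrogen is not required for growth inhibition on the shared core. Going by these compounds alone, the one earlier step, a 2.3-fold lower number from compound 1 to compound 3 (0.37 log units; beyond the scatter), added ethyl at an amide-type nitrogen and also lowered the number, so adding an alkyl in one pair and removing one in the other both go the same way, and no single rule on chain size holds across these two pairs. Nothing available bears on why this step occurs.

On these data alone, with only the butyl and methyl ends in hand, the shape of the trend across ethyl and propyl chains remains open, as does unsubstituted sulfamoyl. In this assay, as far as these compounds go, the effect of a terminal amine or a carboxylic acid on this chain also remains open.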